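This account rests on a few compounds, and the source may have more. Where it says the series, first, only, none or still open, it means among the compounds named here.

Measured in a toxicity assay on KB cells (Homo sapiens) for cytotoxicity, read by fluorescence, with a stated time of 3 days; on this read-out higher numbers stand for an effect only at larger amounts of compound and lower numbers for an effect already at smaller amounts:
- compound 1 `CCCCOC(=O)CNC(=O)[C@H](CSc1ccc([N+](=O)[O-])cc1[N+](=O)[O-])NC(=O)CC[C@H](NC(=O)C(C)C)C(=O)OCCCC`: > 300 uM, a limit
- compound 2 `CCCCOC(=O)CNC(=O)[C@H](CSc1ccc([N+](=O)[O-])cc1[N+](=O)[O-])NC(=O)CC[C@H](NC(=O)COc1ccccc1)C(=O)OCCCC`: > 300 uM, a limit

Compound 2 stands at > 300 uM, which is a limit of the assay and not a number. The same limit holds both measured compounds: the limit of > 300 uM in this assay, at which 2 of the 2 values shown sit.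

Compound 3 `CCCCOC(=O)CNC(=O)[C@H](CSc1ccc([N+](=O)[O-])cc1[N+](=O)[O-])NC(=O)CC[C@H](Nc1ccc([N+](=O)[O-])cc1[N+](=O)[O-])C(=O)OCCCC` carries 2,4-dinitrophenyl in place of (phenoxymethyl)carbonyl on an amine nitrogen.

Among the compounds with values here, the only measured step bearing on this change is a step that the two limits leave unreadable from compound 1 to compound 2. It gives no size to carry over, so any expectation remains loose. No clear shift is expected, with only a modest move towards lower numbers allowed for, and the estimated step is an at least 1.2-fold lower number from compound 2 to compound 3 (0.07 log units; that floor lies within the scatter). A further limit reading is as likely as a number.

For compound 3 the expected value is 250 uM, with an estimated range from 70 uM to 400 uM.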

Compound 3, concentration for half-maximal effect: > 300 uM
Compound 3 was reported as a limit; the forecaster's own chance of this, stated with the estimate: 60%; at least 1.2-fold (0.07 log units) between middle value and limit.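

No step can be read among compound 1, compound 2 and compound 3, since all three sit at the same limit and not at a number: the limit of > 300 uM in this assay, at which 3 of the 3 values shown sit.

The compounds shown leave open whether any of these groups on the amine nitrogen changes the reading in this assay, and by how much.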